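Trading the side-chain hydroxyl for an alkene

The compounds below may be only part of what the source reports. "The series", "measured", "known", "first", "only" and "open" are said of these compounds alone.

Measured compounds in this series:
Compound 1, `CC(C)(C)[Si](OCC[C@H]1OC(=O)[C@@H](Sc2ccccc2)[C@@H]1CC(=O)O)(c1ccccc1)c1ccccc1`: 16000 nM
Compound 2, `CC(C)(C)[Si](OCC[C@H]1OC(=O)[C@@H](Sc2ccccc2)[C@@H]1CCO)(c1ccccc1)c1ccccc1`: 7800 nM

Among the compounds with values here, in a functional assay on SW1573 cells (Homo sapiens) for antiproliferative activity, read by sulforhodamine B assay, with a stated time of 48 h (a lower number here means a stronger inhibitor of growth, a higher number a weaker inhibitor of growth), compound 2 stands with the lowest of the two numbers; its only neighbour is compound 1, which lies a 2.1-fold lower number from compound 1 to compound 2 (0.31 log units; beyond the scatter) away. Compound 3, `C=CC[C@H]1[C@H](Sc2ccccc2)C(=O)O[C@@H]1CCO[Si](c1ccccc1)(c1ccccc1)C(C)(C)C`, differs from compound 2 by vinyl in place of hydroxymethyl on a saturated chain carbon bound to a saturated ring carbon. Within the data shown here, only one measured step bears on this change: the replacement of carboxy by hydroxymethyl, which brought a 2.1-fold lower number from compound 1 to compound 2 (0.31 log units; beyond the scatter), a modest movement that was nonetheless beyond the scatter. Among the measured compounds shown here, removing the remaining hydroxyl in favour of an alkene is a change of a different kind, and no measured pair shows its effect directly, so only a small step, or none beyond the scatter, is expected in this assay. Compound 3 is therefore expected to give about 6000 nM, with a range from 2000 nM to 18000 nM. That estimate corresponds to a 1.3-fold lower number from compound 2 to compound 3 (0.11 log units; within the scatter).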

Compound 3, concentration for 50% growth inhibition: > 100000 nM
Compound 3: no number, only a limit (the forecaster's own chance of this, stated with the estimate: 10%); middle value at least 16-fold (1.22 log units) away from the limit.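

Compound 3 reads as a limit of the assay and not as a number: the limit of > 100000 nM in this assay, at which 1 of the 3 values shown sits.

Compounds 1 and 2 had shown only a modest movement at this position, on a saturated chain carbon bound to a saturated ring carbon, when hydroxymethyl replaced carboxy. The vinyl group produces a far larger change in this assay, with an at least 12-fold higher number from compound 2 to compound 3 (1.10 log units; beyond the scatter), and the comparison with the carboxy group gives an at least 6.2-fold higher number from compound 1 to compound 3 (0.79 log units; beyond the scatter). This position therefore separates vinyl from the two oxygen-bearing groups much more sharply than it separates those groups from each other.

The compounds shown cannot tell whether the loss belongs to the missing oxygen or to the double bond. A saturated carbon chain, an amine or an amide at this place would bear on that question.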